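The compounds below may be only part of what the source reports. "The series", "measured", "known", "first", "only" and "open" are said of these compounds alone.

Compound 1, `O=C(COc1ccc2c(=O)ccoc2c1)Nc1cccc(NC(=O)c2ccc([N+](=O)[O-])cc2)c1`: 67 nM
Compound 2, `Cc1nc(C(=O)Nc2cccc(NC(=O)COc3ccc4c(=O)ccoc4c3)c2)cs1`: 473 nM
Compound 3, `O=C(COc1ccc2c(=O)ccoc2c1)Nc1cccc(NC(=O)c2cnc(C(F)(F)F)s2)c1`: 160 nM

All three share one core and differ only in the group on a carbonyl carbon. In an assay on isolated protein for inhibition of Rho-associated protein kinase 1 (Homo sapiens), read by scintillation counting, radiometric assay and 33P incorporation, with a stated time of 40 min, in the presence of a further agent that is not named here (on this read-out lower numbers stand for stronger inhibition and higher numbers for weaker inhibition), compound 3 gives 160 nM, the second highest number of the three; compound 1 gives 67 nM, the lowest. Compound 4, `O=C(COc1ccc2c(=O)ccoc2c1)Nc1cccc(NC(=O)c2ccc(C(=O)O)cc2)c1`, is not yet measured; it differs from compound 3 by 4-carboxyphenyl in place of 2-(trifluoromethyl)-1,3-thiazol-5-yl on a carbonyl carbon. The closest measured step is a 2.4-fold higher number from compound 1 to compound 3 (0.38 log units; beyond the scatter), which swapped a six-membered carbon ring for the thiazole. Returning to a six-membered ring, now bearing a carboxylic acid instead of a nitro group, is expected to run that step roughly in reverse, a modest lowering of the number, because a 2.4-fold higher number from compound 1 to compound 3 (0.38 log units; beyond the scatter) is the only guide: a 1.6-fold lower number from compound 3 to compound 4 (0.20 log units; within the scatter). Compound 4 is estimated at 100 nM, expected between 30 nM and 400 nM.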

Compound 4, half-maximal inhibitory concentration: 6890 nM
Compound 4: middle estimate off by 69-fold (1.84 log units), on the low side; the whole stated range lies below it.
By their numbers in this assay, from the lowest: compound 1; then compound 3; then compound 2; then compound 4.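

For the compounds shown here, at this position the group on the carbonyl carbon matters far more than the earlier compounds showed: 4-carboxyphenyl gives a 43-fold higher number from compound 3 to compound 4 (1.63 log units; beyond the scatter) and a 15-fold higher number from compound 2 to compound 4 (1.16 log units; beyond the scatter), so it ranks behind both thiazoles. The ring can stay the same and the number still moves sharply, since carboxy in place of nitro on an aromatic carbon gives a 100-fold higher number from compound 1 to compound 4 (2.01 log units; beyond the scatter). Nothing available here explains this loss. Still open, from the compounds shown here alone, is whether it is specific to the carboxylic acid, or whether a methyl ester, a primary amide or a nitrile in place of the carboxy would give a similar number.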